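A few compounds are considered here, and "the series" means these few. Any claim that something is new, unique, unknown or untested is made for them only; others in the source may bear on it.

Measured so far:
compound 1, `O=C(/C=C/c1ccc(/C=N/NC(=O)c2ccncc2)cc1)c1ccc(F)cc1` — 51.1%
compound 2, `COc1ccc(C(=O)/C=C/c2ccc(/C=N/NC(=N)N)cc2)cc1` — 57.2%

In a functional assay on the whole organism (Ear) for inhibition, with Mus musculus as the target, with a stated time of 30 min, at a dose of 100 mg/kg by the intraperitoneal route (a higher number here means more inhibition at the dose given (going by the name of the read-out), a lower number less inhibition), compound 1 gives 51.1% and compound 2 gives 57.2%. Compound 2 stands alongside compound 1; the gap between the two numbers lies within the scatter, so the two numbers count as level. Compound 3, `N=C(N)N/N=C/c1ccc(/C=C/C(=O)c2ccc(F)cc2)cc1`, has not yet been measured. It differs from compound 2 as fluoro in place of methoxy on an aromatic carbon. Among the measured compounds shown here, no step between measured compounds covers this change, so in this assay a shift of no size beyond the scatter, in either direction, is expected. Compound 3 is expected to give 55%, in the range 35% to 72%. The step of a number 2.2 percentage points lower from compound 2 to compound 3 (within the scatter) is thus estimated to stay within the scatter.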

Compound 3, a percentage reported as inhibition, in the whole organism at one dose (the size of the read-out at that dose, not a potency): 90.7%
Beside the measured number, compound 3's estimate is 35.7 percentage points below it; measured number above the stated range.
By their numbers in this assay, from the lowest: compounds 1 and 2 (each within the scatter of the next); then compound 3.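

In this assay, the place on an aromatic carbon para to a large group turns out to matter: going from 4-methoxyphenyl to 4-fluorophenyl gives a number 33.5 percentage points higher from compound 2 to compound 3 (beyond the scatter). With fluoro held fixed, the group on the amine nitrogen matters as well, with a number 39.6 percentage points higher from compound 1 to compound 3 (beyond the scatter), which the level numbers of compound 1 and compound 2 did not reveal. Nothing on hand explains either step. Still open, as far as these compounds go, is whether chloro, methyl or plain hydrogen in place of fluoro keeps a number of this size, and whether an acetyl group on the amine nitrogen does.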